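Aryl change on the carbonyl: compound 1 to compound 4

The source may hold more compounds than are shown below. What is called first, only, known or untested is meant among the compounds shown, and "the series" means these compounds.

compound 1 `CO[C@H]1CC[C@H](NC(=O)c2n[nH]cc2NC(=O)c2cc(Cl)cc(Cl)c2)CC1`: 13000 nM
compound 2 `COc1cccc(OC)c1C(=O)Nc1c[nH]nc1C(=O)NCc1ccccn1`: > 50000 nM (a limit of the assay)
compound 3 `COc1cccc(OC)c1C(=O)Nc1c[nH]nc1C(=O)NCCCN(C)C`: > 50000 nM (a limit of the assay)

For the measured compounds named here, in an ADME assay on MRC5 cells (Homo sapiens) for inhibition, with a stated time of 72 h (a lower number here means that less compound is needed, a higher number that more compound is needed for the effect), compound 1 gives 13000 nM, the only true number in the set. The other two values are limits, not numbers. Next comes compound 4 `COc1ccccc1C(=O)Nc1c[nH]nc1C(=O)N[C@H]1CC[C@H](OC)CC1`. The change is 2-methoxyphenyl in place of 3,5-dichlorophenyl on a carbonyl carbon.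

Going by the values given here, the one measured step, a step that the two limits leave unreadable from compound 2 to compound 3, concerns a saturated chain carbon bound to an amide-type nitrogen, not the carbonyl group that changes here, and it gives no size. Among the compounds with values here, no measured step covers this change directly. Within the data shown here, the only guide is that compound 2 and compound 3 also carry methoxy groups on the phenyl at that carbonyl carbon, and both sit at the limit of > 50000 nM in this assay, at which 2 of the 3 values shown sit. These two also differ from compound 1 elsewhere, so the guide is weak.

A move towards a higher number is expected, and the expected size is a 2.3-fold higher number from compound 1 to compound 4 (0.36 log units; beyond the scatter). A limit reading would also be no surprise. For compound 4 the estimate is 30000 nM, with an expected range of 12000 nM to 50000 nM.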

Compound 4, half-maximal effective concentration: 1500 nM
The estimate for compound 4 lay 20-fold (1.30 log units) above the measured number; the measured number lies below the stated range.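

In this assay, 2-methoxyphenyl in place of 3,5-dichlorophenyl on a carbonyl carbon gives an 8.7-fold lower number from compound 1 to compound 4 (0.94 log units; beyond the scatter) with the rest of the molecule unchanged, so the aryl group at this position alone moves the read-out beyond the scatter. For the compounds shown here, this is the first step with a readable size, as the only earlier step cannot be read. The change removes both chlorine atoms and brings in a hydrogen-bond acceptor, but no measurement shown bears on which of these lies behind the step.

On these data alone, whether the lower number follows from gaining the methoxy group or from losing the chlorine atoms remains open. An unsubstituted phenyl, or a phenyl carrying a single chlorine or a nitrile, at this carbonyl would separate these readings.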